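The source may report more compounds than this note shows. Statements on the series, on what has been measured and on what is new or still open speak of the compounds shown alone.

Measured compounds:
Compound 1 `COc1ccc(CSc2cc(C(F)(F)F)ccc2CNC(=O)C(C)c2ccc(NS(C)(=O)=O)c(F)c2)cc1` gives 2.3 nM in an assay on CHO cells for antagonist activity at transient receptor potential cation channel subfamily V member 1 (Homo sapiens), read by FLIPR; a lower number here means a stronger inhibitor, a higher number a weaker inhibitor.
Compound 2 `CC(C(=O)NCc1ccc(C(F)(F)F)cc1Cl)c1ccc(NS(C)(=O)=O)c(F)c1` gives 4 nM in this assay.

Within the data shown here, compound 2 holds the higher of the two numbers so far, but the gap to compound 1 is small: the step of a 1.7-fold higher number from compound 1 to compound 2 (0.24 log units; within the scatter) lies within the scatter, so the two compounds cannot be ordered on these data.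

Compound 3 `CC(C(=O)NCc1ccc(C(F)(F)F)cc1-c1cccc(Cl)c1)c1ccc(NS(C)(=O)=O)c(F)c1` differs from compound 2 at the same aromatic carbon: 3-chlorophenyl in place of chloro on an aromatic carbon. Among the measured compounds shown here, only one measured step bears on this position, a 1.7-fold higher number from compound 1 to compound 2 (0.24 log units; within the scatter), and it shows that a large substituent and a single chlorine at that carbon give numbers within the scatter of each other in this assay. On that single comparison the account expects the entry of a 3-chlorophenyl group to leave the number roughly where compound 2 stands, with no step beyond the scatter, so the expected step is a 1.1-fold lower number from compound 2 to compound 3 (0.06 log units; within the scatter). Compound 3 is therefore estimated at 3.5 nM in this assay, with a range from 1 nM to 12 nM.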

Compound 3, inhibition constant: 1 nM
The estimate for compound 3 lay 3.5-fold (0.54 log units) above the measured number; the measured number falls inside the stated range.
By their numbers in this assay, from the lowest: compound 3; then compounds 1 and 2 (each within the scatter of the next).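

In this assay, the aromatic carbon meta to a trifluoromethyl group now proves responsive to what it carries: chloro and (4-methoxybenzyl)sulfanyl could not be told apart there, but 3-chlorophenyl in place of chloro gives a 4.0-fold lower number from compound 2 to compound 3 (0.60 log units; beyond the scatter), a modest change that lies beyond the scatter. The same group also separates from the (4-methoxybenzyl)sulfanyl group, with a 2.3-fold lower number from compound 1 to compound 3 (0.36 log units; beyond the scatter), so the number at this carbon does not follow substituent size alone across these three compounds, since the two with the higher numbers carry a single chlorine and a large group. Nothing available accounts for why the 3-chlorophenyl group gives the lowest number of the three.

Still open, going by these compounds, is how much of this step belongs to the ring and how much to its chlorine, a question that a plain phenyl group or a 4-chlorophenyl group at the same carbon would address. On these data alone, it is also open whether a ring containing nitrogen, such as pyridine, or a small amine at this carbon would keep the number as low.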